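The compounds below may be only part of what the source reports. "The series", "measured", "known", "first", "only" and "open" are said of these compounds alone.

Measured compounds:
compound 1 `Cc1nc2ccccc2c(=O)n1/N=C/c1ccc(Oc2ccc(Br)cc2)cc1` – 4.64
compound 2 `Cc1ccc(Oc2ccc(/C=N/n3c(C)nc4ccccc4c3=O)cc2)cc1` – 4.32
compound 3 `CCCc1nc2ccccc2c(=O)n1/N=C/c1ccc(Oc2ccc(Cl)c(C)c2)cc1` – 6.02

In a physicochemical assay for lipophilicity, in phosphate buffer, measured as octanol-water partition (a higher number here means a more lipophilic compound, a lower number a more polar compound), compound 1 gives 4.64, the second highest of the three numbers. Its nearest neighbour is compound 2 with 4.32, and the furthest is compound 3 with 6.02, which differs from compound 1 in more than one place, so the two values are only set side by side here.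

Compound 4 `Cc1nc2ccccc2c(=O)n1/N=C/c1ccc(Oc2ccccc2)cc1` is not yet measured in this assay. It differs from compound 1 in one place: hydrogen in place of bromo on an aromatic carbon. Going by the values given here, the only measured step that bears on this change is the one from compound 1 to compound 2, where methyl replaced bromo at the same place and gave a number 0.32 log units lower from compound 1 to compound 2 (beyond the scatter). Replacing bromo with hydrogen removes the heavy atom altogether rather than swapping it for methyl, so a larger drop than that step is expected, in the same direction.

For compound 4 the expected step is a number 0.84 log units lower from compound 1 to compound 4 (beyond the scatter), beyond the scatter. Compound 4 is therefore estimated at 3.8 in this assay, with a range from 3.4 to 4.3.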

Compound 4, partition coefficient: 4.01
Compound 4: middle estimate off by 0.21 log units, on the low side; low and high end bracket the measured number.
By their numbers in this assay, from the lowest: compound 4; then compound 2; then compound 1; then compound 3.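

With hydrogen on this aromatic carbon, para to a large group, the series gains an unsubstituted reference point in this assay, and the removal of bromo gives a number 0.63 log units lower from compound 1 to compound 4 (beyond the scatter) as a step beyond the scatter. Earlier, only the exchange of bromo for methyl could be read at this place, but the new compound also allows methyl to be compared with hydrogen, giving a number 0.31 log units lower from compound 2 to compound 4 (beyond the scatter) in the same direction, so that hydrogen, methyl and bromo now form an ordered set of three substituents, with a number 0.32 log units lower from compound 1 to compound 2 (beyond the scatter) as the step between the upper two. Nothing available explains this order, and the numbers describe it without accounting for it.

Compound 3 differs from these compounds in more than one place, so its value cannot be divided among its changes and does not show how this order would hold with another chain on the core. From the compounds shown here alone, what a fluoro, a methoxy, an amine or a carboxylic acid would give on this same aromatic carbon remains open, as does whether any of them would fall outside the range spanned by hydrogen and bromo.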